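Amide substituent change in a hydroxyphenyl amide pair

This account rests on a few compounds, and the source may have more. Where it says the series, first, only, none or still open, it means among the compounds named here.

Measured so far:
compound 1 `CC(C)=CCCC1=CC[C@H](C(=O)Nc2ccc(O)cc2)[C@@H](c2ccccc2)C1` — > 23000 nM
compound 2 `CC(C)=CCCC1=CC[C@@H](C(=O)Nc2ccc(O)cc2)[C@H](c2ccccc2)C1` — > 23000 nM

In an assay on isolated protein for inhibition of Apoptosis regulator Bcl-2 (Homo sapiens), read by fluorescence polarization, with stated times of 5 min and 10 min (on this read-out lower numbers stand for stronger inhibition and higher numbers for weaker inhibition), compound 1 returns only the assay limit, > 23000 nM. Compound 2 likewise returns only the limit, > 23000 nM. Compound 1 therefore stands at the limit, with no number to read. Within the data shown here, the one measured step, from compound 1 to compound 2, is a step that the two limits leave unreadable from compound 1 to compound 2; the limit of > 23000 nM in this assay, at which 2 of the 2 values shown sit, and the fact that compounds 1 and 2 differ only in the configuration as drawn are all that is known of it. Compound 3 `CC(C)=CCCC1=CC[C@H](C(=O)NCCC(=O)O)[C@@H](c2ccccc2)C1` carries 2-carboxyethyl in place of 4-hydroxyphenyl on an amide-type nitrogen. Only the unreadable step bears on this change, so no direction can be expected beyond the scatter. Compound 3 is expected to sit at the limit too, estimated at 30000 nM within 8000 nM to 120000 nM. The expected step is a step that the limit leaves unreadable from compound 1 to compound 3.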

Compound 3, inhibition constant: > 23000 nM
Compound 3: only a limit was reported (the forecaster's own chance of this, stated with the estimate: 80%); the middle value does not contradict the limit.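

Compound 3 returns only a limit, > 23000 nM, and the step from compound 1 to it cannot be read. The compounds shown leave open whether 2-carboxyethyl and 4-hydroxyphenyl on the amide-type nitrogen differ at all in inhibition.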